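This account rests on a few compounds, and the source may have more. Where it says the series, first, only, none or still open, it means among the compounds named here.

Working notes on the series.

Compound 1 `CCCS(=O)(=O)Nc1ccc(F)c(C(=O)c2n[nH]c3ncc(-c4ccc(OC)cc4)cc23)c1F` and compound 2 `CCCS(=O)(=O)Nc1ccc(F)c(C(=O)c2n[nH]c3ncc(-c4ccc(Cl)c(Cl)c4)cc23)c1F` share one core and differ only in the aryl group on the fused ring system. In an assay for binding affinity to dual specificity mitogen-activated protein kinase kinase 4 (Homo sapiens), read by KINOMEscan, tested at 100 nM (a higher number here means a weaker effect of the compound at the concentration tested, a lower number a stronger effect), compound 1 gives 4.2%, while compound 2 gives 45%. For the measured compounds named here, this is the step of a number 40.8 percentage points higher from compound 1 to compound 2 (beyond the scatter), so compound 2 stands as the higher of the two numbers, with compound 1 the only neighbour and well beyond the scatter below it.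

Compound 3 `CCCS(=O)(=O)Nc1ccc(F)c(C(=O)c2n[nH]c3ncc(-c4ccc(C(C)C)cc4)cc23)c1F` has not yet been measured. The change from compound 2 is 4-isopropylphenyl in place of 3,4-dichlorophenyl on an aromatic carbon. Going by the values given here, the single measured step that bears on it is a number 40.8 percentage points higher from compound 1 to compound 2 (beyond the scatter), which shows that the choice of aryl group moves the read-out by a large amount; whether 4-isopropylphenyl behaves more like 4-methoxyphenyl or like 3,4-dichlorophenyl cannot be read from two compounds. The expected step is a number 25 percentage points lower from compound 2 to compound 3 (beyond the scatter), downward, with a wide range. For compound 3 the estimate in this assay is 20%, between 3% and 60%.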

Compound 3, a percentage reported as activity, at one concentration (the size of the read-out at that concentration, not a potency): 17%
For compound 3 the middle estimate is 3 percentage points above the measured one; the range from low to high includes it.
By their numbers in this assay, from the lowest: compound 1; then compound 3; then compound 2.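

In this assay, a number 28 percentage points lower from compound 2 to compound 3 (beyond the scatter) and a number 12.8 percentage points higher from compound 1 to compound 3 (beyond the scatter) place 4-isopropylphenyl at a third level, so these three aryl groups on the shared core give a graded read-out rather than two separate states. The 3,4-dichlorophenyl and 4-isopropylphenyl groups each count no hydrogen-bond donors or acceptors yet still differ beyond the scatter, so that count does not separate this pair. Nothing measured here accounts for the order of the three aryl groups.

The compounds shown leave open how an amine or a carboxylic acid on this aryl ring would read, and whether a chain longer than isopropyl would move the number further in either direction. They also leave open whether a pyridine ring in place of the phenyl ring would keep the level of any of these three compounds.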